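A few compounds are considered here, and "the series" means these few. Any claim that something is new, unique, unknown or untested is made for them only; others in the source may bear on it.

Of the compounds shown here, three have been tested so far in a functional assay on the whole organism with Mus musculus as the target (a lower number here means that less compound is needed, a higher number that more compound is needed for the effect), and none of them gives an exact number. Compound 1 (`CN1C(=O)CCC1(O)c1ccc(C(F)(F)F)cc1`) reads > 200 mg/kg, which is a limit of the assay. Compound 2 (`CCN1C(=O)CCC1(O)c1cccc(C(F)(F)F)c1`) reads > 100 mg/kg, also a limit. Compound 3 (`CC(C)NC(=O)CCC(=O)c1cccc(C(F)(F)F)c1`) reads > 200 mg/kg, again a limit. Compound 3 therefore stands at the limit of > 200 mg/kg in this assay, at which 2 of the 3 values shown sit.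

The next compound to be tested is compound 4 (`O=C(CCC(=O)c1cccc(C(F)(F)F)c1)NC1CCCCC1`). It differs from compound 3 in one place, with cyclohexyl in place of isopropyl on an amide-type nitrogen. Going by the values given here, no pair of tested compounds shows what a change of this kind does, so the expectation rests on little. The expected step, a number no higher from compound 3 to compound 4 (the limit leaves the size open), is no larger than the usual scatter, and neither direction is favoured. Another limit would fit this expectation as well as a number would. For compound 4 the estimated value in this assay is 200 mg/kg, with an expected range from 80 mg/kg to 400 mg/kg.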

Compound 4, dose for half-maximal effect: > 200 mg/kg
Compound 4: only a limit was reported; the forecaster's own chance of this, stated with the estimate: 60%; the middle value lies on the limit itself.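

In this assay, going by these compounds alone, compound 3 and compound 4 both give only a limit of the assay and not a number, so no step between them can be read. The compounds shown leave open whether cyclohexyl in place of isopropyl on the amide-type nitrogen changes the dose needed.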